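This account rests on a few compounds, and the source may have more. Where it says the series, first, only, none or still open, it means among the compounds named here.

Compound 1 `CCC(CO)Nc1nc(NCc2ccccc2)c2nc(Br)n(C(C)C)c2n1`: 53000 nM
Compound 2 `CCC(CO)Nc1nc(NCc2ccccc2)c2nc(N)n(C(C)C)c2n1`: 60000 nM
Compound 3 `CCC(CO)Nc1nc(NCc2ccccc2)c2nc(S)n(C(C)C)c2n1`: 55000 nM

In a functional assay on MCF7 cells (Homo sapiens) for cytotoxicity (on this read-out higher numbers stand for weaker inhibition and lower numbers for stronger inhibition), compound 3 gives 55000 nM and stands level with the other two compounds: the data show a 1.0-fold higher number from compound 1 to compound 3 (0.02 log units; within the scatter) and a 1.1-fold lower number from compound 2 to compound 3 (0.04 log units; within the scatter). Compound 4 `CCC(CO)Nc1nc(NCc2ccccc2)c2nc([N+](=O)[O-])n(C(C)C)c2n1` has nitro in place of sulfanyl on an aromatic carbon. The three measured swaps at this same carbon bear most directly on it, and the third, a 1.1-fold higher number from compound 1 to compound 2 (0.05 log units; within the scatter), was just as small. Among the measured compounds shown here, no nitro compound has been measured, so the range stays wide. The expected result is no change at the digits printed from compound 3 to compound 4 (within the scatter), with no change beyond the scatter expected in this assay. For compound 4, the estimated value is 55000 nM, within an expected range of 25000 nM to 110000 nM.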

Compound 4, half-maximal inhibitory concentration: 117000 nM
Compound 4: the middle estimate sits 2.1-fold (0.33 log units) below what was measured, outside the stated range (above it).
By their numbers in this assay, from the lowest: compounds 1, 3, 2 and 4 (each within the scatter of the next, the first and the last beyond it).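

In this assay this carbon is not wholly indifferent to what it carries: nitro is the only group shown here whose steps pass the scatter, with a 2.1-fold higher number from compound 3 to compound 4 (0.33 log units; beyond the scatter) and a 2.2-fold higher number from compound 1 to compound 4 (0.34 log units; beyond the scatter) in this comparison. Against the amino compound the gap stays inside the scatter, with a 2.0-fold higher number from compound 2 to compound 4 (0.29 log units; within the scatter) as the printed step, so the shift is modest at best. No measurement at hand accounts for this shift. As far as these compounds go, whether a carboxylic acid, a nitrile or a methyl group on this carbon would move the number further stays open.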